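This account rests on a few compounds, and the source may have more. Where it says the series, first, only, none or still open, it means among the compounds named here.

Measured compounds:
compound 1 `CCCCCCCCCCC(C)(C)C(=O)Nc1ccc(C)cc1C`; in an assay on microsomes from intestine for inhibition of acyl-CoA:cholesterol acyltransferase (Oryctolagus cuniculus) (on this read-out lower numbers stand for stronger inhibition and higher numbers for weaker inhibition), compound 1 gives 680 nM
compound 2 `CCCCCCCCCCC(C)(C)C(=O)Nc1ccc(C)c(C)c1`; in this assay compound 2 gives 1660 nM
compound 3 `CCCCCCCCCCC(C)(C)C(=O)Nc1c(C)cccc1C`; in this assay compound 3 gives 1300 nM

Compound 3 holds the second highest of the three numbers. Its nearest neighbour is compound 2, with a 1.3-fold lower number from compound 2 to compound 3 (0.11 log units; within the scatter); the furthest is compound 1, with a 1.9-fold higher number from compound 1 to compound 3 (0.28 log units; within the scatter). Both gaps lie within the scatter, so no order among these pairs is claimed; only a 2.4-fold higher number from compound 1 to compound 2 (0.39 log units; beyond the scatter) separates two compounds beyond it.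

Compound 4 `CCCCCCCCCCC(C)(C)C(=O)Nc1c(C)cccc1OCC` arises from compound 3 by ethoxy in place of methyl on an aromatic carbon. None of the three measured steps exchanges a methyl for an oxygen-bearing group; each merely moves methyls around the ring on the amide-type nitrogen, and all of those moves stayed modest. Going by the values given here, the set holds no precedent for this change, and no measured step speaks to it directly. The working expectation is therefore a small shift in this assay, of roughly the size of the measured steps, with the direction left open. Compound 4 is estimated at 1600 nM (range 600 nM to 4500 nM), which would correspond to an expected 1.2-fold higher number from compound 3 to compound 4 (0.09 log units; within the scatter) that need not exceed the scatter.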

Compound 4, half-maximal inhibitory concentration: 180 nM
Compound 4: middle estimate off by 8.9-fold (0.95 log units), on the high side; the measured number lies below the stated range.
By their numbers in this assay, from the lowest: compound 4; then compounds 1, 3 and 2 (each within the scatter of the next, the first and the last beyond it).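

In this assay, going by these compounds alone, the position ortho to a large group proves responsive to what it carries: ethoxy in place of methyl gives a 7.2-fold lower number from compound 3 to compound 4 (0.86 log units; beyond the scatter) and so moves the number beyond the scatter, whereas the earlier steps only moved methyls around the ring. The entering group differs from methyl both in size and in bringing an oxygen with a hydrogen-bond acceptor, and this single step does not separate the two. Nothing available gives a reason for the step.

Whether the oxygen or the ethyl part accounts for the step remains open, and methoxy, propoxy or a plain propyl chain at this place would separate them. Also open, as far as these compounds go, is whether the remaining methyl of compound 4 contributes, which a hydrogen or a chlorine in its place would address.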